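Fluoro to methoxy on the anilide of a chromone ether

The compounds below may be only part of what the source reports. "The series", "measured", "known", "first", "only" and "open" are said of these compounds alone.

Measured compounds:
compound 1 `O=C(COc1ccc2oc(-c3ccccc3)cc(=O)c2c1)Nc1ccc2ccccc2c1` gives 6710 nM in a functional assay on NCI-H661 cells (Homo sapiens) for antiproliferative activity, read by MTT assay, with a stated time of 72 h; a lower number here means a stronger inhibitor of growth, a higher number a weaker inhibitor of growth
compound 2 `O=C(COc1ccc2oc(-c3ccccc3)cc(=O)c2c1)Nc1ccc(F)cc1` gives 1470 nM in this assay

For the measured compounds named here, compound 2 stands lowest of the two numbers so far, and its nearest neighbour is compound 1, which lies higher by a 4.6-fold lower number from compound 1 to compound 2 (0.66 log units; beyond the scatter). That single measured step shows that exchanging the naphthalen-2-yl group on the amide-type nitrogen for a 4-fluorophenyl group gives a modestly lower number.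

Compound 3 `COc1ccc(NC(=O)COc2ccc3oc(-c4ccccc4)cc(=O)c3c2)cc1` keeps the shared core and the amide linkage of compound 2 and differs only in one place: methoxy in place of fluoro on an aromatic carbon, on an aromatic carbon of a six-membered aromatic ring of carbon only. Going by the values given here, no measured step touches a change of this kind; the only step available concerns a much larger change of ring system, so it bears on the present question only loosely. With nothing in the data pointing to either direction, the expectation for compound 3 in this assay is a step no larger than the scatter, a 1.2-fold higher number from compound 2 to compound 3 (0.09 log units; within the scatter). Compound 3 is therefore estimated at 1800 nM, with a likely range from 700 nM to 5000 nM.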

Compound 3, concentration for 50% growth inhibition: 840 nM
For compound 3 the middle estimate is 2.1-fold (0.33 log units) above the measured one; measured number inside the range.
By their numbers in this assay, from the lowest: compounds 3 and 2 (each within the scatter of the next); then compound 1.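

In this assay the exchange on an aromatic carbon para to a large group gives a 1.8-fold lower number from compound 2 to compound 3 (0.24 log units; within the scatter), so in this measurement fluoro and methoxy at this position cannot be told apart, even though methoxy carries 1 hydrogen-bond acceptor where fluoro carries 0. The comparison with the larger group now reads an 8.0-fold lower number from compound 1 to compound 3 (0.90 log units; beyond the scatter), and together with a 4.6-fold lower number from compound 1 to compound 2 (0.66 log units; beyond the scatter) it places both 4-fluorophenyl and 4-methoxyphenyl on the amide-type nitrogen beyond the scatter from naphthalen-2-yl, which leaves compound 1 as the weakest of the three. No other measurement here bears on how these steps should be interpreted.

The compounds shown leave open whether an amine, a carboxylic acid or a longer alkoxy chain at this same position would stay within the scatter of fluoro and methoxy, or would move the number clearly in either direction. They also leave open what a chloro or methoxy group would do on the phenyl ring of the shared core, which is the same in all three compounds.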